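Isomeric bicyclic amines on a shared core: clearance notes

The compounds below may be only part of what the source reports. "The series", "measured", "known", "first", "only" and "open" are said of these compounds alone.

Measured so far:
compound 1 `COc1cc(N2CCN(C(=O)CN3Cc4ccccc4C3)CC2)ccc1-c1cnc(C)o1` gives 42 mL.min-1.g-1
compound 2 `COc1cc(N2CCN(C(=O)N[C@@H](C)c3cccc4ccccc34)CC2)ccc1-c1cnc(C)o1` gives 130 mL.min-1.g-1

In an ADME assay on microsomes from liver (Rattus norvegicus) for metabolic stability, read by LC-MS (on this read-out higher numbers stand for fast clearance and lower numbers for slow clearance), compound 1 stands lowest of the two numbers; compound 2 sits higher, beyond the usual scatter. Compound 3 `COc1cc(N2CCN(C(=O)CN3CCc4ccccc43)CC2)ccc1-c1cnc(C)o1` differs from compound 1 by a group of 9 heavy atoms (8 carbon, 1 nitrogen; one five-membered non-aromatic ring with 1 hetero atom, one six-membered aromatic ring of carbon only) in place of a group of 9 heavy atoms (8 carbon, 1 nitrogen; one five-membered non-aromatic ring with 1 hetero atom, one six-membered aromatic ring of carbon only), on a saturated chain carbon bound to a carbonyl carbon, the two having the same atoms joined differently. Among the compounds with values here, no measured pair shows this rearrangement, so its effect in this assay cannot be read from the data; a step within the scatter, in either direction, is expected. Compound 3 is therefore estimated at 50 mL.min-1.g-1, with a range of 20 mL.min-1.g-1 to 125 mL.min-1.g-1. The expected step is a 1.2-fold higher number from compound 1 to compound 3 (0.08 log units; within the scatter).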

Compound 3, intrinsic clearance in microsomes: 160 mL.min-1.g-1
Compound 3: middle estimate off by 3.2-fold (0.51 log units), on the low side; measured number outside the range, above it.
By their numbers in this assay, from the lowest: compound 1; then compounds 2 and 3 (each within the scatter of the next).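

At this place, on a saturated chain carbon bound to a carbonyl carbon, the arrangement of the atoms alone moves the clearance read-out: in this assay the change to 2,3-dihydro-1H-indol-1-yl gives a 3.8-fold higher number from compound 1 to compound 3 (0.58 log units; beyond the scatter) with no change in the heavy-atom, ring, donor or acceptor counts. The earlier compounds shown here, which differ in more than one place, could not separate such a rearrangement from other changes. Nothing at hand bears on the reason for this rise.

Open, on these data alone, is how a dimethylamino group or a longer chain ending in an amine at this same place would stand against compound 1 and compound 3 in this assay. Also open, as far as these compounds go, is whether the step holds on any other core.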